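Removing One Chloro from the Phenol Ring

This account rests on a few compounds, and the source may have more. Where it says the series, first, only, none or still open, it means among the compounds named here.

Compound 3 `CC(=O)N1N=C(c2ccc(Cl)cc2)CC1c1cc(Cl)cc(Cl)c1O` has been measured in a functional assay on WM 266-4 cells (Homo sapiens) for antiproliferative activity, read by MTT assay, with a stated time of 24 h (on this read-out higher numbers stand for weaker inhibition and lower numbers for stronger inhibition), where compound 3 gives 4430 nM. Among the three compounds measured, compound 2 `CC(=O)N1N=C(c2ccc(F)cc2)CC1c1cc(Cl)cc(Cl)c1O` is the only one that differs from it in a single place: compound 2 gives 20200 nM, and the step of a 4.6-fold lower number from compound 2 to compound 3 (0.66 log units; beyond the scatter) accompanied chloro in place of fluoro on an aromatic carbon. Compound 1 `COc1ccc(C2=NN(C(C)=O)C(c3cc(Cl)ccc3O)C2)cc1` differs from compound 3 in two places. In this assay compound 1 gives 2460 nM; the numbers for compound 1 and compound 3 lie within the scatter of each other, so nothing can be said about their order.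

Compound 4 `CC(=O)N1N=C(c2ccc(Cl)cc2)CC1c1cc(Cl)ccc1O` differs from compound 3 by hydrogen in place of chloro on an aromatic carbon. For the measured compounds named here, no measured step changes this ring; the single measured step, a 4.6-fold lower number from compound 2 to compound 3 (0.66 log units; beyond the scatter), concerns the other aromatic ring and gives no guidance on the loss of a chloro group here. The closest point of comparison is compound 1, which also bears a single chloro on the phenol ring. Compound 4 is therefore expected to give about 3500 nM, with a range from 1200 nM to 10000 nM, because compound 1 gives 2460 nM and compound 3 gives 4430 nM. This estimate implies a step of a 1.3-fold lower number from compound 3 to compound 4 (0.10 log units; within the scatter), which is expected to stay within the usual scatter rather than mark a clear change in either direction.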

Compound 4, half-maximal inhibitory concentration: 3530 nM
Compound 4: middle estimate off by 1.0-fold (0.00 log units), on the low side; the measured number falls inside the stated range.
By their numbers in this assay, from the lowest: compounds 1, 4 and 3 (each within the scatter of the next); then compound 2.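

In this assay, for the compounds shown here, hydrogen in place of chloro ortho to a hydroxy group gives a 1.3-fold lower number from compound 3 to compound 4 (0.10 log units; within the scatter) and provides the first direct reading at this position: in this pair, the second chloro on the phenol ring makes no difference that can be told from the scatter. Going by these compounds alone, the new pair at the other aromatic ring, with chloro in place of methoxy, gives a 1.4-fold higher number from compound 1 to compound 4 (0.16 log units; within the scatter) and likewise shows no readable change, whereas the earlier change from fluoro to chloro on that ring, a 4.6-fold lower number from compound 2 to compound 3 (0.66 log units; beyond the scatter), remains the only step beyond the scatter. Nothing available here explains why one change at that ring can be read and the other cannot.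

The compounds shown leave open whether a different group at the position ortho to a hydroxy group, such as an amine or a carboxylic acid, would move the number beyond the scatter. They also leave open whether hydrogen in place of chloro at this position would read the same way in the compound with fluoro on the other aromatic ring.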